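A Propargyl Thioether Triazole Awaiting Cytotoxicity Testing

The compounds below may be only part of what the source reports. "The series", "measured", "known", "first", "only" and "open" are said of these compounds alone.

Compound 1 `Cc1ccc(C(=O)CSc2nnc(C)n2N2C(=O)c3ccccc3C2=O)cc1` and compound 2 `C#CCSc1nnc(C)n1N1C(=O)c2ccccc2C1=O` share a core and differ by ethynyl in place of (4-methylphenyl)carbonyl on a saturated chain carbon bound to a sulfur. In a functional assay on PC-3M cells (Homo sapiens) for cytotoxicity, read by MTT assay, with a stated time of 48 h (on this read-out higher numbers stand for weaker inhibition and lower numbers for stronger inhibition), compound 1 gives only a limit of the assay, > 200000 nM. Compound 2 likewise reaches only a limit, > 200000 nM. The step that the two limits leave unreadable from compound 1 to compound 2 cannot be sized because of the limit of > 200000 nM in this assay, at which 3 of the 3 values shown sit. Compound 3 `CCCc1nnc(SCC(=O)c2ccc(C)cc2)n1N1C(=O)c2ccccc2C1=O` differs from compound 1 by ethyl in place of hydrogen on a saturated chain carbon bound to an aromatic carbon. In this assay compound 3 also returns only a limit, > 200000 nM. Compound 4 `C#CCSc1nnc(CCC)n1N1C(=O)c2ccccc2C1=O` differs from compound 3 by ethynyl in place of (4-methylphenyl)carbonyl on a saturated chain carbon bound to a sulfur, the same change that separates compound 1 from compound 2. Going by the values given here, with all three values sitting at the limit and no step that can be sized, compound 4 is expected to behave in the same way, and the expected step that the limit leaves unreadable from compound 3 to compound 4 rests on nothing more than that. Compound 4 is therefore estimated at 300000 nM, between 100000 nM and 1000000 nM, most likely reported only as a limit.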

Compound 4, half-maximal inhibitory concentration: > 200000 nM
Compound 4 gave a limit, no number; the forecaster's own chance of this, stated with the estimate: 85%; the middle value lies beyond the limit too.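

No step can be read from compound 2 or compound 3 to compound 4, because all of these compounds give only a limit: the limit of > 200000 nM in this assay, at which 4 of the 4 values shown sit.

The compounds shown leave open whether either change, ethynyl or ethyl, has any effect in this assay.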